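A phenyl group takes the place of cyano

This account rests on a few compounds, and the source may have more. Where it says the series, first, only, none or still open, it means among the compounds named here.

Compound 2 `N#Cc1ccc(OCCCOc2ccc3c(O)c([N+](=O)[O-])c(=O)oc3c2)cc1` was tested in a functional assay on ileum (Cavia porcellus) for antagonist activity; on this read-out lower numbers stand for stronger inhibition and higher numbers for weaker inhibition. Compound 2 gives > 10000 nM, which is a limit and not a number. Compound 1 `COc1ccc(OCCCOc2ccc3c(O)c([N+](=O)[O-])c(=O)oc3c2)cc1` gives > 4000 nM, which is also a limit. Within the data shown here, the only measured comparison is a step that the two limits leave unreadable from compound 1 to compound 2, so no step size can be carried forward.

Compound 3 `O=c1oc2cc(OCCCOc3ccc(-c4ccccc4)cc3)ccc2c(O)c1[N+](=O)[O-]` changes one place in compound 2: phenyl in place of cyano on an aromatic carbon. In words, this is phenyl in place of cyano on an aromatic carbon, para to a large group. Among the measured compounds shown here, no measured step covers this exchange, so neither a size nor a direction in this assay can be firmly expected. Compound 3 is expected to remain a weak inhibitor because compound 2 sits at the limit > 10000 nM. The expected change is an at least 1.2-fold lower number from compound 2 to compound 3 (0.09 log units; that floor lies within the scatter), though this is only a rough estimate. Compound 3 is estimated at 8000 nM, within an expected range from 1500 nM to 30000 nM.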

Compound 3, half-maximal inhibitory concentration: > 20000 nM
Compound 3: no number, only a limit (the forecaster's own chance of this, stated with the estimate: 65%); middle value at least 2.5-fold (0.39 log units) away from the limit.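

Among these compounds, compound 1, compound 2 and compound 3 each give only a limit and not a number, so no step between them can be read. On these data alone, how strongly any of the three inhibits, and whether methoxy, cyano or phenyl at this place makes any difference, stays open.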